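Chloro in Place of Methoxy: Expecting Little Change

The source may hold more compounds than are shown below. What is called first, only, known or untested is meant among the compounds shown, and "the series" means these compounds.

compound 1 `COc1ccc(/C=C/C(=O)c2sc(Nc3ccc(Cl)cc3)nc2C)cc1`: > 25000 nM
compound 2 `Cc1cccc(Nc2nc(C)c(C(=O)/C=C/c3ccccc3Cl)s2)c1`: > 25000 nM

In a functional assay on Bel-7402 cells (Homo sapiens) for cytotoxicity, read by MTT assay (a lower number here means a stronger inhibitor, a higher number a weaker inhibitor), compound 1 gives > 25000 nM, which is a limit of the assay rather than a number. Compound 2 gives > 25000 nM, likewise a limit. Both values sit at the limit of > 25000 nM in this assay, at which 2 of the 2 values shown sit, so compound 1 cannot be placed higher or lower than any measured partner. Compound 3 `Cc1nc(Nc2ccc(Cl)cc2)sc1C(=O)/C=C/c1ccc(Cl)cc1` differs from compound 1 by chloro in place of methoxy on an aromatic carbon. Going by the values given here, no measured step of this kind exists here, so the change is expected to stay within the scatter: a step that the limit leaves unreadable from compound 1 to compound 3. Compound 3 is therefore estimated at 30000 nM, between 8000 nM and 100000 nM, most likely reported again as a limit.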

Compound 3, half-maximal inhibitory concentration: > 25000 nM
Compound 3: no number, only a limit; the forecaster's own chance of this, stated with the estimate: 75%; the middle value is on the limit's open side.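

Going by these compounds alone, compound 1 and compound 3 both stop at a limit of the assay rather than a number, so no step between them can be read: the limit of > 25000 nM in this assay, at which 3 of the 3 values shown sit.

In this assay the compounds shown leave open how strong any of them is and whether chloro in place of methoxy changes anything.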